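A few compounds are considered here, and "the series" means these few. Any claim that something is new, unique, unknown or untested is made for them only; others in the source may bear on it.

Among the compounds with values here, compound 1 `O=C(Nc1cccc(OCc2ccc(-c3ccccc3)cc2)c1)C1CCNCC1` is the only member of this small set with a number attached: in a functional assay on a cell-free system (Platelet, plasma, Homo sapiens) for inhibition (a higher number here means a weaker inhibitor, a lower number a stronger inhibitor), compound 1 gives 54000 nM, which places it among weak inhibitors. Compound 2 `O=C(Nc1cccc(OCc2ccc(-c3ccccc3F)cc2)c1)C1CCNCC1` shares the core of compound 1 and carries a 2-fluorophenyl in place of the plain phenyl, but in this assay compound 2 gives "not determined" (no result reported), so no single number marks where it stands. Compound 3 `O=C(Nc1cccc(OCc2ccc(-c3cc(F)cc(F)c3)cc2)c1)C1CCNCC1` differs from compound 2 in one place (3,5-difluorophenyl in place of 2-fluorophenyl on an aromatic carbon). Within the data shown here, with no measured step between any two compounds in this assay, there is no basis for expecting a change beyond the usual scatter in either direction; the expectation rests on the value of compound 1 alone. Compound 3 is therefore expected to be a weak inhibitor as well, with an estimated value of 40000 nM in a range from 10000 nM to 150000 nM.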

Compound 3, half-maximal inhibitory concentration: 17000 nM
Beside the measured number, compound 3's estimate is 2.4-fold (0.37 log units) above it; the range from low to high includes it.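

In this assay, replacing phenyl with 3,5-difluorophenyl, on an aromatic carbon para to a large group, gives a 3.2-fold lower number from compound 1 to compound 3 (0.50 log units; beyond the scatter) and so shows that this position can respond to substitution, although compound 3 at 17000 nM remains a weak inhibitor. The step between compound 2 and compound 3 cannot be read, as compound 2 carries no number, so the 2-fluorophenyl cannot be placed relative to either the phenyl or the 3,5-difluorophenyl. Nothing among the data offered accounts for the lower number seen with the two fluorines.

The compounds shown leave open whether one fluorine at either of these ring positions would give the same step or whether both are needed. They also leave open how chlorine, methoxy or trifluoromethyl at the same ring positions would compare in this assay with the 3,5-difluorophenyl of compound 3.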